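The source may hold more compounds than are shown below. What is called first, only, known or untested is meant among the compounds shown, and "the series" means these compounds.

Measured so far in an assay on isolated protein for displacement of a labelled ligand from galanin receptor type 3 (Homo sapiens); on this read-out higher numbers stand for weaker inhibition and lower numbers for stronger inhibition:
compound 1 `CN(C)CCCOc1cccc(N2C(=O)/C(=N/c3cccc(C(F)(F)F)c3)c3ccccc32)c1` gives 29 nM
compound 2 `CCN(CC)CCCCOc1cccc(N2C(=O)/C(=N/c3cccc(C(F)(F)F)c3)c3ccccc32)c1` gives 45 nM

Compound 2 has the higher of the two numbers, but it sits close to compound 1: the step of a 1.6-fold higher number from compound 1 to compound 2 (0.19 log units; within the scatter) falls within the usual scatter, so the two cannot be told apart on this evidence. Compound 3 `CCN(CC)COc1cccc(N2C(=O)/C(=N/c3cccc(C(F)(F)F)c3)c3ccccc32)c1` takes the next step from compound 2, namely (diethylamino in place of 3-(diethylamino)propyl on a saturated chain carbon bound to an oxygen on an aromatic ring). This shortens the link between the oxygen on the aromatic ring and the nitrogen-bearing amine, while the amine itself is unchanged. Among the measured compounds shown here, only one measured step bears on it, the change from compound 1 to compound 2, and that step was small. For the measured compounds named here, that step altered both the chain length and the amine substituents together and still left the number nearly where it was, which suggests the shared core tolerates some variation here; a shortening of this size, however, has no direct precedent among the two measured compounds. The expected change for compound 3 is therefore a modest rise, a 2.4-fold higher number from compound 2 to compound 3 (0.39 log units; beyond the scatter). Compound 3 is estimated at 110 nM, within a range from 30 nM to 400 nM.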

Compound 3, inhibition constant in the galanin receptor type 3 assay: 38 nM
For compound 3 the middle estimate is 2.9-fold (0.46 log units) above the measured one; the measured number falls inside the stated range.
By their numbers in the galanin receptor type 3 assay, from the lowest: compounds 1, 3 and 2 (each within the scatter of the next).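

Replacing 4-(diethylamino)butoxy with (diethylamino)methoxy gives no readable effect in the galanin receptor type 3 assay (a 1.2-fold lower number from compound 2 to compound 3 (0.07 log units; within the scatter)). The amine is the same on both sides of this step. Among the compounds shown here, the earlier step from compound 1 to compound 2 changed the amine and the chain together, so this is the first view of chain length alone, and on this evidence compound 2 and compound 3 cannot be told apart. Nor can the remaining pair be told apart in the galanin receptor type 3 assay (a 1.3-fold higher number from compound 1 to compound 3 (0.12 log units; within the scatter)). In a physicochemical assay for solubility, at pH 7.4 (on this read-out higher numbers stand for higher solubility and lower numbers for lower solubility), compound 2 gives 5 ug/mL and compound 3 gives 48 ug/mL. The change from 4-(diethylamino)butoxy to (diethylamino)methoxy does register in the physicochemical assay, where the shorter chain goes with the higher number: the measured solubility of compound 2, 5 ug/mL, and of compound 3, 48 ug/mL, a 9.6-fold higher number (0.98 log units; beyond the scatter).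

All three compounds shown carry an open-chain amine with small alkyl groups, so they leave open whether binding also holds when a ring amine such as morpholine or piperidine, or a carboxylic acid, stands in place of the diethylamino group. On these data alone, with only compound 2 and compound 3 to compare in the physicochemical assay, it also remains open whether the solubility follows chain length across other lengths, such as a 2-(diethylamino)ethoxy chain, or belongs to this one pair.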